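Series notes: amide for sulfonamide on the shared core

A few compounds are considered here, and "the series" means these few. Any claim that something is new, unique, unknown or untested is made for them only; others in the source may bear on it.

Compound 1 `CN(C1CC1)S(=O)(=O)c1cncc(C(=O)N[C@@H](CC(=O)O)C(=O)CSCc2ccc(F)cc2)c1` gives 22000 nM in a functional assay on NT2 cells (Homo sapiens) for inhibition; a higher number here means a weaker inhibitor, a lower number a stronger inhibitor. Among the three measured compounds it holds the second highest number. The nearest is compound 2 `O=C(O)C[C@H](NC(=O)c1cncc(S(=O)(=O)NC2CC2)c1)C(=O)CNCc1c(F)cccc1F`, which gives 53000 nM in this assay, a higher number and beyond the scatter. The furthest is compound 3 `O=C(O)C[C@H](NC(=O)c1cncc(S(=O)(=O)NC2CC2)c1)C(=O)COC(=O)c1cccc2ccccc12`, which gives 1300 nM in this assay, a lower number and also beyond the scatter. For the measured compounds named here, none of these three pairs differs in a single place, so no measured step bears on the change below.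

Compound 4 `CCCN(CCC)C(=O)c1cncc(C(=O)N[C@@H](CC(=O)O)C(=O)CSCc2ccc(F)cc2)c1` is not yet measured. It differs from compound 1 by dipropylcarbamoyl in place of cyclopropyl(methyl)sulfamoyl on an aromatic carbon. Going by the values given here, no measured pair shows a change of this kind, and the three values give no direction for it. The step of a 1.1-fold lower number from compound 1 to compound 4 (0.04 log units; within the scatter) is therefore expected to be small, with no direction beyond the scatter. Compound 4 is estimated at 20000 nM, with a range from 6000 nM to 70000 nM, taking the value of compound 1, 22000 nM, as the anchor.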

Compound 4, half-maximal inhibitory concentration: > 100000 nM
Compound 4: only a limit was reported (the forecaster's own chance of this, stated with the estimate: 15%); middle value at least 5.0-fold (0.69 log units) from the limit.
By their numbers in this assay, from the lowest: compound 3; then compound 1; then compound 2. At a limit, above all of these: compound 4.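

In this assay, dipropylcarbamoyl in place of cyclopropyl(methyl)sulfamoyl on this aromatic carbon gives an at least 4.5-fold higher number from compound 1 to compound 4 (0.65 log units; beyond the scatter), the only single-place change shown, so activity at this position depends on the group it carries. For compound 4 the reported > 100000 nM is a limit, not a number. From the compounds shown here alone, the step is therefore a minimum, and its full size stays unknown: the limit of > 100000 nM in this assay, at which 1 of the 4 values shown sits.

The change removes the sulfur, the three-membered ring and one hydrogen-bond acceptor and adds two propyl chains in a single move, so the data cannot say which of these matters. A dimethylcarbamoyl or a dipropylsulfamoyl group on the same carbon would separate the carbonyl-for-sulfonyl swap from the change in the groups on nitrogen.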